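Nitro to Methyl: Expected Cytotoxicity of Compound 4

A few compounds are considered here, and "the series" means these few. Any claim that something is new, unique, unknown or untested is made for them only; others in the source may bear on it.

Of the compounds shown here, three have been tested in an ADME assay on RAW264.7 cells (Mus musculus) for cytotoxicity, read by MTT assay, with a stated time of 48 h; on this read-out lower numbers stand for higher toxicity in this test and higher numbers for lower toxicity in this test. Compound 1, `CC(=O)OC[C@H]1O[C@H](OC[C@@H](Cn2cc(CN(c3nc(-c4cccc([N+](=O)[O-])c4)no3)C3CCCCC3)nn2)OC(C)=O)C=C[C@@H]1OC(C)=O`, gives 100 ug/mL, the highest of the three numbers, so it is the least toxic of the three in this test. Compound 2, `C#CCN(c1nc(-c2ccccc2)no1)C1CCCCC1`, gives 32.1 ug/mL, a lower number, and the gap to compound 1 lies beyond the usual scatter. Compound 3, `C#Cc1ccc(-c2noc(NC3CCCCC3)n2)cc1`, gives 19.8 ug/mL, the lowest number and the furthest from compound 1, again beyond the scatter. Among the compounds with values here, compound 2 and compound 3 differ from compound 1 in several places at once, so no single-change step between measured compounds is available.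

Compound 4, `CC(=O)OC[C@H]1O[C@H](OC[C@@H](Cn2cc(CN(c3nc(-c4cccc(C)c4)no3)C3CCCCC3)nn2)OC(C)=O)C=C[C@@H]1OC(C)=O`, differs from compound 1 in one place: methyl in place of nitro on an aromatic carbon. The exchange sits on an aromatic carbon of a six-membered aromatic ring of carbon only, meta to a large group, while the large remainder of the molecule is kept. Within the data shown here, no measured pair shows this exchange, so its effect in this assay is unknown. Given that compound 1 gives 100 ug/mL and that the change is small against the whole molecule, the step of no change at the digits printed from compound 1 to compound 4 (within the scatter) is expected to be small, in either direction, and likely none beyond the scatter. Compound 4 is therefore estimated at 100 ug/mL, with a range from 45 ug/mL to 200 ug/mL.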

Compound 4, half-maximal cytotoxic concentration: 46.4 ug/mL
Estimate against measurement, compound 4: 2.2-fold (0.33 log units) above; low and high end bracket the measured number.
By their numbers in this assay, from the lowest: compounds 3, 2 and 4 (each within the scatter of the next, the first and the last beyond it); then compound 1.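

The exchange of 3-nitrophenyl for 3-methylphenyl gives, in this assay, a 2.2-fold lower number from compound 1 to compound 4 (0.33 log units; beyond the scatter), so a change at this one place on the aromatic ring registers in the read-out even though the large remainder of the molecule stays the same. The earlier compounds shown here could not show this: each differs from compound 1 in several places at once, so no shift in their numbers could be tied to a single group. The step here is modest and runs towards higher toxicity in this test, but nothing available gives a reason for that direction.

Going by these compounds, a single pair gives only two points at this place on the ring, so it remains open whether other groups there, such as an amine, a chlorine atom or a methoxy group, would give numbers closer to compound 1 or to compound 4. On these data alone, it is also open whether the same exchange of nitro for methyl would shift the number in the same direction and by a similar amount on a different core, or whether this step holds only for the core of compound 1.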